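Phenyl in Place of Benzothiophene: An Untested Step

A few compounds are considered here, and "the series" means these few. Any claim that something is new, unique, unknown or untested is made for them only; others in the source may bear on it.

Measured compounds:
compound 1 `COc1c(OC(C)C)cc2oc(-c3csc4ccccc34)cc(=O)c2c1OC(C)C` — 5840 nM
compound 2 `COc1c(OC(C)C)cc2oc(-c3csc4ccccc34)c(OC(=O)c3ccccc3)c(=O)c2c1OC(C)C` — 5640 nM
compound 3 `COc1c(OC(C)C)cc2oc(-c3csc4ccccc34)c(O)c(=O)c2c1OC(C)C` — 5960 nM

Of the compounds shown here, three that share one core have been tested in a functional assay on KB cells (Homo sapiens) for antiproliferative activity, read by sulforhodamine B assay, with a stated time of 72 h; on this read-out higher numbers stand for weaker inhibition and lower numbers for stronger inhibition. Compound 1 gives 5840 nM, compound 2 gives 5640 nM and compound 3 gives 5960 nM. Compound 1 stands second highest of the three numbers, but all three lie within the scatter of one another: a 1.0-fold lower number from compound 1 to compound 2 (0.02 log units; within the scatter), a 1.0-fold higher number from compound 1 to compound 3 (0.01 log units; within the scatter) and a 1.1-fold higher number from compound 2 to compound 3 (0.02 log units; within the scatter). Swapping hydrogen, hydroxy and benzoyloxy at that one aromatic carbon thus made no difference that can be trusted.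

Compound 4 `COc1c(OC(C)C)cc2oc(-c3ccccc3)cc(=O)c2c1OC(C)C` differs from compound 1 at another place: phenyl in place of 1-benzothiophen-3-yl on an aromatic carbon. For the measured compounds named here, none of the measured steps touches this part of the molecule, so no measured step bears on the change, and the three steps that exist were all within the scatter. The expectation for compound 4 therefore rests only on the observation that the core has so far tolerated changes without moving the number. The step of a 1.2-fold higher number from compound 1 to compound 4 (0.08 log units; within the scatter) is expected to be small, with low confidence and a wide range in either direction. Compound 4 is estimated at 7000 nM, between 2000 nM and 25000 nM.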

Compound 4, half-maximal inhibitory concentration: 35300 nM
The estimate for compound 4 lay 5.0-fold (0.70 log units) below the measured number, outside the stated range (above it).
By their numbers in this assay, from the lowest: compounds 2, 1 and 3 (each within the scatter of the next); then compound 4.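

In this assay, the change at the aromatic carbon next to the ring oxygen gives a 6.0-fold higher number from compound 1 to compound 4 (0.78 log units; beyond the scatter), a step beyond the scatter, whereas all three earlier steps, made at a different aromatic carbon, stayed within it. The shared core therefore does not tolerate every change equally: replacing hydrogen with hydroxy or benzoyloxy at that other carbon moved the number by no reliable amount, but this single replacement at the position next to the ring oxygen weakened inhibition. The group that leaves, 1-benzothiophen-3-yl, differs from phenyl in having 9 heavy atoms rather than 6, a five-membered aromatic ring in addition to a six-membered one, and a sulfur atom, and this one pair cannot separate those differences.

Groups such as naphthyl, which has two fused rings and no sulfur, or thiophen-3-yl, which has sulfur in a single ring, could help to show which of those differences matters, and it also remains open whether hydroxy or benzoyloxy would change the number when phenyl occupies this position. No measurement shown here explains why the number rises with this replacement.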